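This account rests on a few compounds, and the source may have more. Where it says the series, first, only, none or still open, it means among the compounds named here.

Measured compounds and their values:

compound 1, `COc1cc(C(=O)/C=C/c2cn(C)c3ccccc23)cc(N)c1OC` — 289 nM
compound 2, `COc1cc(C(=O)/C(C)=C/c2c[nH]c3ccccc23)cc([Se]C)c1OC` — 18 nM
compound 3, `COc1ccc2c(/C=C/C(=O)c3cc(OC)c(OC)c([N+](=O)[O-])c3)cn(C)c2c1` — 562 nM

Of the compounds shown here, three have been tested in a functional assay on MHCC97H cells (Homo sapiens) for antiproliferative activity, read by MTT assay, with a stated time of 48 h; a lower number here means a stronger inhibitor, a higher number a weaker inhibitor. Compound 2 gives the lowest number of the three with 18 nM. Its nearest neighbour is compound 1, whose number is higher by a margin beyond the scatter, and compound 3 sits furthest away, also beyond the scatter. Since each of these three compounds differs from the others in more than one place, none of the gaps can be tied to a single structural change.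

Compound 4, `COc1ccc2c(/C=C(\C)C(=O)c3cc(OC)c(OC)c([Se]C)c3)c[nH]c2c1`, has not been measured. It differs from compound 2 in one place: methoxy in place of hydrogen on an aromatic carbon. Compound 3 also carries a methoxy at this place, but it differs from compound 2 elsewhere too, so its value says nothing clean about this one change. Within the data shown here, with no measured pair showing the effect of this methoxy alone, the expected step from compound 2 to compound 4 in this assay is small, probably within the scatter, in either direction: a 1.2-fold higher number from compound 2 to compound 4 (0.09 log units; within the scatter). On that basis compound 4 is estimated at 22 nM, with a likely range from 8 nM to 65 nM.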

Compound 4, half-maximal inhibitory concentration: 6 nM
For compound 4 the middle estimate is 3.7-fold (0.56 log units) above the measured one, and the stated range ends above it.
By their numbers in this assay, from the lowest: compound 4; then compound 2; then compounds 1 and 3 (each within the scatter of the next).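

Replacing hydrogen with methoxy on an aromatic carbon of the fused two-ring system gives, in this assay, a 3.0-fold lower number from compound 2 to compound 4 (0.48 log units; beyond the scatter), the first change among these compounds that can be read on its own. The step lies beyond the scatter, so this place, meta to a fused ring and para to a fused ring, does more than accept the added methoxy: with the rest of compound 2 kept unchanged, the number falls rather than rises. No measurement of any other property bears on this step, so it stands as an observation without an explanation.

Among these compounds, only one group has been compared with hydrogen here, so it remains open whether a hydroxyl, a fluorine or a longer chain such as ethoxy at the same place would lower the number as well, or raise it. The effect of methoxy is also known from this single pair alone, which leaves open whether it would carry over to a core such as that of compound 1.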